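Quinazoline thioacetamide anilides: acrylamide analogue with halogenated aniline

A few compounds are considered here, and "the series" means these few. Any claim that something is new, unique, unknown or untested is made for them only; others in the source may bear on it.

Measured so far:
- compound 1, `O=C(CSc1nc(Nc2ccccc2)c2ccccc2n1)Nc1ccc(C(F)(F)F)cc1`: 11100 nM
- compound 2, `C=CC(=O)Nc1cccc(NC(=O)CSc2nc(Nc3cccc(Br)c3)c3ccccc3n2)c1`: 19400 nM

Both numbers come from a functional assay on MDA-MB-231 cells (Homo sapiens) for inhibition, read by MTT assay, with a stated time of 72 h; a lower number here means a stronger inhibitor, a higher number a weaker inhibitor. Compound 2, with 19400 nM in this assay, and compound 1, with 11100 nM, lie within the scatter of each other, so the two measurements show no separation; neither can be called the stronger inhibitor on this evidence.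

Compound 3, `C=CC(=O)Nc1cccc(NC(=O)CSc2nc(Nc3ccc(F)c(Cl)c3)c3ccccc3n2)c1`, has not yet been measured in this assay. It differs from compound 2 in one place: 3-chloro-4-fluorophenyl in place of 3-bromophenyl on a nitrogen on an aromatic ring. The shared core, the thioacetamide linker and the acrylamide-bearing anilide are unchanged.

For the measured compounds named here, no step between measured compounds is available to calibrate this change, so the expectation rests on compound 2 alone. The step from compound 2 to compound 3 is expected to be small, in either direction, and not beyond the scatter: a 1.1-fold lower number from compound 2 to compound 3 (0.03 log units; within the scatter). On that basis compound 3 is expected to give 18000 nM in this assay, with a range from 7000 nM to 45000 nM, the value of compound 2 at 19400 nM being the only anchor.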

Compound 3, half-maximal inhibitory concentration: 10600 nM
The estimate for compound 3 lay 1.7-fold (0.23 log units) above the measured number; measured number inside the range.
By their numbers in this assay, from the lowest: compounds 3, 1 and 2 (each within the scatter of the next).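

In this assay, for the compounds shown here, this is the first comparison that differs in one place only: 3-chloro-4-fluorophenyl in place of 3-bromophenyl on the nitrogen gives a 1.8-fold lower number from compound 2 to compound 3 (0.26 log units; within the scatter), so this exchange does not separate the two compounds at this position. The step carries the loss of bromine and the gain of chlorine and fluorine together, and no share of it can be assigned to any one of these atoms. Nothing at hand bears on the reason for the size of this step.

Going by these compounds, whether any substituent on this ring can move the number beyond the scatter remains open, since the two groups compared here are both halogenated phenyl rings, and a methoxy group, an amine or a carboxylic acid on that ring would test a different kind of group. Compound 1 differs from compound 2 and compound 3 in more than one place, so the part played by the acrylamide remains unread, and a propanamide in its place with the aniline substituent held constant would isolate it.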